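Shrinking the Ring Amine: From Pyrrolidine to Azetidine

The source may report more compounds than this note shows. Statements on the series, on what has been measured and on what is new or still open speak of the compounds shown alone.

In a functional assay on MGC-803 cells (Homo sapiens) for inhibition, read by sulforhodamine B assay (a lower number here means a stronger inhibitor, a higher number a weaker inhibitor), three compounds have been measured so far:
compound 1 `CCc1ccc(NC2=CC(=O)c3nc4n(c3C2=O)[C@H]2OC[C@@H](O)[C@H]2OC4)cc1` gives 1290 nM
compound 2 `O=C1C=C(Nc2ccc(Br)cc2)C(=O)c2c1nc1n2[C@H]2OC[C@@H](O)[C@H]2OC1` gives 1010 nM
compound 3 `O=C1C=C(N2CCCC2)C(=O)c2c1nc1n2[C@H]2OC[C@@H](O)[C@H]2OC1` gives only a limit of the assay, > 16000 nM

Compounds 1 and 2 sit close together, as a 1.3-fold lower number from compound 1 to compound 2 (0.11 log units; within the scatter) shows. Compound 3 stands apart: for it the assay returned no number, only a limit, and the limit of > 16000 nM in this assay, at which 1 of the 3 values shown sits, marks where that limit lies. The two steps leading to it are large losses, an at least 12-fold higher number from compound 1 to compound 3 (1.09 log units; beyond the scatter) and an at least 15-fold higher number from compound 2 to compound 3 (1.19 log units; beyond the scatter), both from an aryl-amino group to pyrrolidin-1-yl.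

Compound 4 `O=C1C=C(N2CCC2)C(=O)c2c1nc1n2[C@H]2OC[C@@H](O)[C@H]2OC1` differs from compound 3 by azetidin-1-yl in place of pyrrolidin-1-yl on a double-bonded ring carbon. No measured step exchanges one small non-aromatic nitrogen ring for another, so nothing shown bears directly on this change; the only steps at this position are the two large drops just mentioned, which both end at a cyclic amine of this sort. Compound 4 is therefore expected to remain at or near the limit, and the step of a number no higher from compound 3 to compound 4 (the limit leaves the size open) is estimated to be none beyond the scatter. For compound 4 the estimate is 16000 nM, with a range from 5000 nM to 50000 nM.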

Compound 4, half-maximal inhibitory concentration: > 16000 nM
Compound 4 ended at the assay's limit (the forecaster's own chance of this, stated with the estimate: 65%); the middle value sits exactly at the limit.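

The loss seen with pyrrolidin-1-yl is not confined to that one ring: in this assay, azetidin-1-yl on the same double-bonded ring carbon also brings a large drop from the aryl-amino compounds, with an at least 15-fold higher number from compound 2 to compound 4 (1.19 log units; beyond the scatter) and an at least 12-fold higher number from compound 1 to compound 4 (1.09 log units; beyond the scatter). Compound 3 and compound 4 each return only a limit of the assay, not a number; the step between them cannot be read, and the two rings cannot be placed in order. The two compounds carrying these small ring amines now share a single reading: the limit of > 16000 nM in this assay, at which 2 of the 4 values shown sit.

The compounds shown leave open which part of the aryl-amino group matters, as each of the active compounds has both an aromatic ring and a hydrogen on the nitrogen, while both compounds at the limit lack the two together. A cyclohexylamino group would keep that nitrogen hydrogen without the aromatic ring, an N-methylanilino group would keep the aromatic ring without the hydrogen, and either could begin to separate the two parts.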